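The source may report more compounds than this note shows. Statements on the series, on what has been measured and on what is new or still open speak of the compounds shown alone.

Compound 1 `COc1ccc(C2=Nc3c(C(C)(C)C)nn(CCCO)c3C(=O)NC2)cc1-c1ccc(C(=O)O)cc1` and compound 2 `COc1ccc(-c2cc(C3=Nc4c(C(C)(C)C)nn(CCCO)c4C(=O)NC3)ccc2OC)c(OC)c1` share one core and differ at a single aromatic carbon. In an ADME assay on microsomes from liver (Homo sapiens) for metabolic stability (on this read-out lower numbers stand for a shorter-lived compound and higher numbers for a longer-lived compound), compound 1 gives 2 h, and compound 2 gives 2 h; the step of no change at the digits printed from compound 1 to compound 2 (within the scatter) shows that a 2,4-dimethoxyphenyl in place of a 4-carboxyphenyl left the half-life unchanged within the scatter. Compound 2 therefore stands level with compound 1 on this read-out. Compound 3 `COc1ccc(OC)c(-c2cc(C3=Nc4c(C(C)(C)C)nn(CCCO)c4C(=O)NC3)ccc2OC)c1` is the next compound in the series: 2,5-dimethoxyphenyl in place of 2,4-dimethoxyphenyl on an aromatic carbon. The two structures hold the same atoms, joined differently. Going by the values given here, only one measured step bears on a change at this aromatic carbon, no change at the digits printed from compound 1 to compound 2 (within the scatter), and it was flat even though a 4-carboxyphenyl gave way to a 2,4-dimethoxyphenyl. Compound 3 is therefore expected to show no step beyond the scatter in this assay, with no change at the digits printed from compound 2 to compound 3 (within the scatter). Compound 3 is estimated at 2 h, within a range from 1 h to 4 h.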

Compound 3, half-life: 1.02 h
Compound 3: the middle estimate sits 2.0-fold (0.29 log units) above what was measured; measured number inside the range.
By their numbers in this assay, from the lowest: compounds 3, 1 and 2 (each within the scatter of the next).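

In this assay, rearranging the same atoms within the aryl group, with 2,5-dimethoxyphenyl in place of 2,4-dimethoxyphenyl, gives a 2.0-fold lower number from compound 2 to compound 3 (0.29 log units; within the scatter); this position has now been probed by an isomeric change as well as by an exchange of groups. With 2,5-dimethoxyphenyl in place of 4-carboxyphenyl, the same read-out gives a 2.0-fold lower number from compound 1 to compound 3 (0.29 log units; within the scatter), so the three aryl groups shown on this aromatic carbon all lie within the scatter of one another. No measurement given here accounts for these numbers.

On these data alone, whether a phenyl ring carrying an amine or a trifluoromethyl group on this aromatic carbon would stay within that scatter remains open. The compounds shown also leave open how a phenyl ring with a single methoxy group, or with none, would read in this assay here.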